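Aryl amide cap of the leucine series: dichlorophenyl replacement

The source may hold more compounds than are shown below. What is called first, only, known or untested is meant among the compounds shown, and "the series" means these compounds.

Compound 2 `CC(C)C[C@H](NC(=O)c1ccc2ccccc2n1)C(=O)N[C@H]1CCN(Cc2ccc(OCCCN(C)C)cc2)C1` carries a quinoline carbonyl on the leucine nitrogen. In an assay on HEK293 cells for binding affinity to Urotensin-2 receptor (Homo sapiens), read by radioligand binding (on this read-out lower numbers stand for stronger inhibition and higher numbers for weaker inhibition), compound 2 gives 631 nM, the highest of the two numbers recorded so far. For the measured compounds named here, its nearest neighbour is compound 1 `CC(C)C[C@H](NC(=O)c1cc2ccccc2o1)C(=O)N[C@H]1CCN(Cc2ccc(OCCCN(C)C)cc2)C1`, which in this assay gives 158 nM; the single measured step is a 4.0-fold higher number from compound 1 to compound 2 (0.60 log units; beyond the scatter), a swap of one bicyclic aromatic group for another.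

Compound 3 `CC(C)C[C@H](NC(=O)c1ccc(Cl)c(Cl)c1)C(=O)N[C@H]1CCN(Cc2ccc(OCCCN(C)C)cc2)C1` is the next variation at the same position: 3,4-dichlorophenyl in place of quinolin-2-yl on a carbonyl carbon. Going by the values given here, no measured pair covers a bicyclic-to-monocyclic exchange at this carbonyl, so the only guidance is the step from compound 1 to compound 2, which shows that changes of the aryl cap move the number by a modest amount in either direction. On that basis compound 3 is expected to land at a 2.1-fold lower number from compound 2 to compound 3 (0.32 log units; beyond the scatter) relative to compound 2, a move back toward the region of compound 1 rather than further out, with wide uncertainty. The estimate for compound 3 in this assay is 300 nM, with a range from 80 nM to 1200 nM.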

Compound 3, inhibition constant: 126 nM
Estimate against measurement, compound 3: 2.4-fold (0.38 log units) above, within the range that was stated.
By their numbers in this assay, from the lowest: compounds 3 and 1 (each within the scatter of the next); then compound 2.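

In this assay, the step of a 5.0-fold lower number from compound 2 to compound 3 (0.70 log units; beyond the scatter) shows that a bicyclic cap is not needed at this carbonyl: 3,4-dichlorophenyl, with its single six-membered aromatic ring, can take the place of quinolin-2-yl and give a lower number. The step of a 1.3-fold lower number from compound 1 to compound 3 (0.10 log units; within the scatter) places 3,4-dichlorophenyl and 1-benzofuran-2-yl within the scatter of each other, so among these three caps, quinolin-2-yl alone stands apart, with both other caps beyond the scatter from it. No supporting data are available to explain the difference between quinolin-2-yl and the other two caps.

Still open, on these data alone, is how much of the number for compound 3 depends on the two chlorines, a question that plain phenyl, a phenyl cap with one chlorine, or methyl or trifluoromethyl groups in place of the chlorines would address. Also open, as far as these compounds go, is whether the ring nitrogen of quinolin-2-yl goes with the higher number of compound 2, which a comparison with a naphthyl cap at the same carbonyl would test.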